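Swapping quinolin-8-yl for trifluoromethoxyphenyl on the sulfonyl

The source may hold more compounds than are shown below. What is called first, only, known or untested is meant among the compounds shown, and "the series" means these compounds.

Three measured compounds share a core and differ only in the group on a sulfonyl sulfur. In an ADME assay (liver) for metabolic stability, with Liver microsome (Homo sapiens) as the target, using microsomes, with a stated time of 30 min, tested at 1 uM (a higher number here means that more of the compound is left, a lower number that less of the compound is left), compound 1 `COc1cccc(S(=O)(=O)c2ccc(CN/C(=N\C#N)Nc3ccncc3)cc2)c1` gives 55%, compound 2 `N#C/N=C(\NCc1ccc(S(=O)(=O)N2CC3CCC(C2)O3)cc1)Nc1ccncc1` gives 60%, and compound 3 `N#C/N=C(\NCc1ccc(S(=O)(=O)c2cccc3cccnc23)cc1)Nc1ccncc1` gives 10%, the lowest of the three. The steps of a number 45 percentage points lower from compound 1 to compound 3 (beyond the scatter) and a number 50 percentage points lower from compound 2 to compound 3 (beyond the scatter) were both large. Compound 4 `N#C/N=C(\NCc1ccc(S(=O)(=O)c2cccc(OC(F)(F)F)c2)cc1)Nc1ccncc1` carries 3-(trifluoromethoxy)phenyl in place of quinolin-8-yl on a sulfonyl sulfur. The entering group, like the 3-methoxyphenyl of compound 1, is one six-membered aromatic ring of carbon only, so the change is expected to roughly reverse the step of a number 45 percentage points lower from compound 1 to compound 3 (beyond the scatter) and give a large rise in this assay. The step from compound 3 to compound 4 is expected to be a number 40 percentage points higher from compound 3 to compound 4 (beyond the scatter). Compound 4 is estimated at 50%, within 30% to 70%.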

Compound 4, percent of the compound remaining: 45%
Compound 4: the middle estimate sits 5 percentage points above what was measured, and the stated range covers the measured number.
By their numbers in this assay, from the lowest: compound 3; then compounds 4, 1 and 2 (each within the scatter of the next, the first and the last beyond it).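

In this assay a second group with one six-membered aromatic ring of carbon only gives a number 35 percentage points higher from compound 3 to compound 4 (beyond the scatter) and so joins compound 1 in standing clear of quinolin-8-yl. Trifluoromethyl in place of methyl on the oxygen gives a number 10 percentage points lower from compound 1 to compound 4 (within the scatter) so the two groups cannot be told apart here, while a number 15 percentage points lower from compound 2 to compound 4 (beyond the scatter) shows that the non-aromatic group of compound 2 keeps a modest lead over the new one. From the compounds shown here alone, whether an amine or a carboxylic acid on that aromatic ring would give a similar number stays open. Nothing shown here explains these differences.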